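The source may hold more compounds than are shown below. What is called first, only, known or untested is meant among the compounds shown, and "the series" means these compounds.

Compound 1 `O=C(Nc1ccccc1)c1cnc(NCc2c(F)ccc3c2CCO3)n2cnnc12` has been examined in an ADME assay on microsomes from liver (Homo sapiens) for metabolic stability, read by LC-MS, using NADPH, with stated times of 5 min and 30 min, tested at 1 uM (a higher number here means faster removal of the compound, a lower number slower removal), where compound 1 gives 14 mL.min-1.g-1. Two other members of the set share its core carrying the same side chain: compound 2 `Cn1cc(-c2cnc(NCc3c(F)ccc4c3CCO4)c3cn[nH]c(=O)c23)cn1` gives 21 mL.min-1.g-1 in this assay, and compound 3 `Cc1ncccc1-c1cnc(NCc2c(F)ccc3c2CCO3)c2n[nH]c(=O)n12` gives 8 mL.min-1.g-1. Compound 1 lies among these numbers, and neither compound 2 nor compound 3 stands apart from it beyond the usual scatter. Compound 4 `O=C(Nc1cnc(NCc2c(F)ccc3c2CCO3)n2cnnc12)c1cccnc1` has not yet been measured; it differs from compound 1 by ((pyridin-3-yl)carbonyl)amino in place of phenylcarbamoyl on an aromatic carbon. Within the data shown here, with no measured pair showing this change, the step from compound 1 to compound 4 is expected to stay within the scatter, as a 1.2-fold lower number from compound 1 to compound 4 (0.07 log units; within the scatter). Compound 4 is estimated at 12 mL.min-1.g-1, between 5 mL.min-1.g-1 and 30 mL.min-1.g-1.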

Compound 4, intrinsic clearance in microsomes: < 3 mL.min-1.g-1
Compound 4 ended at the assay's limit (the forecaster's own chance of this, stated with the estimate: 5%); at least 4.0-fold (0.60 log units) between middle value and limit.
By their numbers in this assay, from the lowest: compounds 3, 1 and 2 (each within the scatter of the next, the first and the last beyond it). At a limit, below all of these: compound 4.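

Among these compounds, with ((pyridin-3-yl)carbonyl)amino in place of phenylcarbamoyl on this aromatic carbon, this assay shows an at least 4.6-fold lower number from compound 1 to compound 4 (0.66 log units; beyond the scatter), the only step here between compounds differing in one place, and it lies beyond the scatter. The earlier compounds shown here showed no step at this position. Its full size cannot be read, as compound 4 sits at a limit of the assay: the limit of < 3 mL.min-1.g-1 in this assay, at which 1 of the 4 values shown sits.

The change reverses the amide and brings in the pyridine nitrogen together, and the compounds shown do not separate the two. Benzoylamino or (pyridin-3-yl)carbamoyl at this position would remain open.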